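The source may report more compounds than this note shows. Statements on the series, on what has been measured and on what is new or still open speak of the compounds shown alone.

Of the compounds shown here, two have numbers so far. Compound 1 (`CCOC(=O)c1csc2nc(CN3CCN(C)CC3)c(-c3ccc(OC)cc3)n12`) gives 35100 nM in a functional assay on HeLa cells (Homo sapiens) for antiproliferative activity, read by MTT assay, with a stated time of 72 h (on this read-out lower numbers stand for stronger inhibition and higher numbers for weaker inhibition), and compound 2 (`Cc1ccc(-c2c(CN3CCCCC3)nc3scc(C(=O)O)n23)cc1`) gives 7630 nM on the same read-out. Compound 2 thus holds the lower of the two numbers, with a gap to compound 1 that lies beyond the usual scatter. Among the compounds with values here, no measured pair differs in one place only, so no single change has been sized yet.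

Compound 3 (`O=C(O)c1csc2nc(CN3CCCCC3)c(-c3ccc(Br)cc3)n12`) carries one change from compound 2, bromo in place of methyl on an aromatic carbon (bromo in place of methyl on an aromatic carbon, para to a large group), so that 4-methylphenyl becomes 4-bromophenyl. Within the data shown here, with no measured step to go on, the expectation in this assay is a small change within the scatter and no firm direction. That expectation rests on compound 2 at 7630 nM and on the structural change alone. The expected move is a 1.3-fold lower number from compound 2 to compound 3 (0.10 log units; within the scatter) and would stay within the scatter. For compound 3 the estimated value is 6000 nM (expected range 2200 nM to 18000 nM).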

Compound 3, half-maximal inhibitory concentration: 76600 nM
For compound 3 the middle estimate is 13-fold (1.11 log units) below the measured one; measured number above the stated range.
By their numbers in this assay, from the lowest: compound 2; then compound 1; then compound 3.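

In this assay, within the data shown here, this is the first single change that can be sized: replacing 4-methylphenyl with 4-bromophenyl gives a 10-fold higher number from compound 2 to compound 3 (1.00 log units; beyond the scatter), so the read-out is sensitive to the group at this place on the aromatic ring, para to a large group. Methyl and bromo each count as one heavy atom, with no ring, no hydrogen-bond donors or acceptors and no net charge, so these counts do not separate the two groups, even though the step lies beyond the scatter. No measurement available here bears on what lies behind the step.

With only methyl and bromo compared at this place on an otherwise unchanged structure, the result gives a single step and no trend across substituents, leaving open where chloro, fluoro or a nitrile would fall. As far as these compounds go, it also remains open whether a step of this size would persist if the rest of the structure changed, for example with a morpholine on the side chain or a primary amide in place of the carboxylic acid.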